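Replacing nitro with fluoro in compound 3

This account rests on a few compounds, and the source may have more. Where it says the series, first, only, none or still open, it means among the compounds named here.

Three compounds share one core and differ only in a single group on an aromatic carbon: compound 1 (`O=C(CCN1CCN(c2ccc(C(F)(F)F)cc2)CC1)c1csc2ccc(F)cc12`), compound 2 (`O=C(CCN1CCN(c2ccc(Cl)cc2)CC1)c1csc2ccc(F)cc12`) and compound 3 (`O=C(CCN1CCN(c2ccc([N+](=O)[O-])cc2)CC1)c1csc2ccc(F)cc12`). Measured in an ADME assay on Vero cells (Chlorocebus sabaeus) for cytotoxicity, with a stated time of 72 h (on this read-out lower numbers stand for stronger inhibition and higher numbers for weaker inhibition), compound 1 gives 896000 nM as its value, compound 2 gives 246000 nM and compound 3 gives 554000 nM as its value. Compound 3 sits close to the trifluoromethyl member (a 1.6-fold lower number from compound 1 to compound 3 (0.21 log units; within the scatter)) and apart from the chloro member (a 2.3-fold higher number from compound 2 to compound 3 (0.35 log units; beyond the scatter)).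

Compound 4 (`O=C(CCN1CCN(c2ccc(F)cc2)CC1)c1csc2ccc(F)cc12`) has not been measured yet. It carries fluoro in place of nitro on an aromatic carbon, para to a large group (fluoro in place of nitro on an aromatic carbon). Within the data shown here, no fluoro compound has been tested, so the closest guide is chloro, the other halogen in this small set. The nearest measured step (a 2.3-fold higher number from compound 2 to compound 3 (0.35 log units; beyond the scatter)) was modest, and so was the largest swap at this carbon (a 3.6-fold lower number from compound 1 to compound 2 (0.56 log units; beyond the scatter)). A small move toward lower numbers therefore seems likely, probably not beyond the scatter. The expected step is small (a 1.4-fold lower number from compound 3 to compound 4 (0.14 log units; within the scatter)). In this assay compound 4 is estimated at 400000 nM (expected range 170000 nM to 900000 nM).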

Compound 4, half-maximal inhibitory concentration: 759000 nM
Estimate against measurement, compound 4: 1.9-fold (0.28 log units) below; low and high end bracket the measured number.
By their numbers in this assay, from the lowest: compound 2; then compounds 3, 4 and 1 (each within the scatter of the next).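

In this assay, putting fluoro in place of nitro on this aromatic carbon gives no readable change (a 1.4-fold higher number from compound 3 to compound 4 (0.14 log units; within the scatter)), and the same holds for fluoro in place of trifluoromethyl (a 1.2-fold lower number from compound 1 to compound 4 (0.07 log units; within the scatter)), so compound 1, compound 3 and compound 4 cannot be told apart here. What is new is that one halogen is a poor guide to another at this position: fluoro in place of chloro is a real step (a 3.1-fold higher number from compound 2 to compound 4 (0.49 log units; beyond the scatter)), which leaves compound 2 alone with the lowest number of the four, while the other three groups, despite their different atoms and sizes, read the same. Nothing measured here accounts for why chloro alone parts from the other three groups.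

Going by these compounds, whether bromo would read like chloro or like fluoro remains open, as does what an amine or a carboxylic acid on this carbon would do. All four compounds also share the same core, so these results cannot say whether chloro would stand apart in the same way on a different core.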